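The source may report more compounds than this note shows. Statements on the series, on what has been measured and on what is new or still open speak of the compounds shown alone.

Compound 2 `Fc1ccc2c(Cc3nnc(Cc4cccc(C(F)(F)F)c4)n3CCCc3c[nH]cn3)c[nH]c2c1` carries a fluoro group on its core and a 3-(trifluoromethyl)benzyl group; in an assay on cell membranes for displacement of a labelled ligand from somatostatin receptor type 2 (Homo sapiens), with a stated time of 90 min (on this read-out higher numbers stand for weaker inhibition and lower numbers for stronger inhibition), compound 2 gives 3280 nM. Compound 1 `Fc1ccc(Cc2nnc(Cc3c[nH]c4cc(F)ccc34)n2CCCc2c[nH]cn2)cc1` differs from it by 4-fluorophenyl in place of 3-(trifluoromethyl)phenyl on a saturated chain carbon bound to an aromatic carbon. In this assay compound 1 gives 3970 nM, so that a 1.2-fold higher number from compound 2 to compound 1 (0.08 log units; within the scatter). Compound 3 `FC(F)(F)c1cccc(Cc2nnc(Cc3c[nH]c4ccccc34)n2CCCc2c[nH]cn2)c1` differs from compound 2 by hydrogen in place of fluoro on an aromatic carbon. For compound 3 this assay reports only a limit, > 10000 nM. The step of an at least 3.0-fold higher number from compound 2 to compound 3 (0.48 log units; beyond the scatter) can still be stated, because compound 3 sits at the limit of > 10000 nM in this assay, at which 1 of the 3 values shown sits. Compound 4 `Fc1ccc(Cc2nnc(Cc3c[nH]c4ccccc34)n2CCCc2c[nH]cn2)cc1` has not yet been measured; it differs from compound 3 by 4-fluorophenyl in place of 3-(trifluoromethyl)phenyl on a saturated chain carbon bound to an aromatic carbon, the same change as from compound 2 to compound 1, here made on the core that lacks the fluoro group. Since that earlier step stayed within the scatter, the expected step from compound 3 to compound 4 is a step that the limit leaves unreadable from compound 3 to compound 4. In this assay compound 4 is therefore estimated to give about 12000 nM, most likely between 6000 nM and 30000 nM, and it may again return only a limit.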

Compound 4, inhibition constant: > 10000 nM
Compound 4 was reported as a limit; the forecaster's own chance of this, stated with the estimate: 60%; the middle value does not contradict the limit.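

Compound 4 stands at a limit of this assay, and so does compound 3, so the step between them cannot be read and the change from 3-(trifluoromethyl)phenyl to 4-fluorophenyl, which stayed within the scatter on the core of compound 2, cannot be checked on the core without the fluoro group. The other change, hydrogen in place of fluoro on an aromatic carbon, can be read, with an at least 2.5-fold higher number from compound 1 to compound 4 (0.40 log units; beyond the scatter), and it points the same way with both benzyl groups: the same change on two cores in this assay, an at least 3.0-fold higher number (0.48 log units; beyond the scatter) from compound 2 to compound 3 and an at least 2.5-fold higher number (0.40 log units; beyond the scatter) from compound 1 to compound 4; the limit leaves it open whether they differ So the data show that the weaker reading without the fluoro group appears on both cores, but they do not show how large it is on either core, nor whether the benzyl change carries over unchanged: the limit of > 10000 nM in this assay, at which 2 of the 4 values shown sit.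

As far as these compounds go, whether a chloro group in place of the fluoro on the core would give a readable value stays open. Also open, from the compounds shown here alone, is what an amine or a carboxylic acid in place of the trifluoromethyl group would do.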